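A few compounds are considered here, and "the series" means these few. Any claim that something is new, unique, unknown or untested is made for them only; others in the source may bear on it.

Measured compounds:
compound 1 `O=C(O)COc1ccc(NC(=O)COc2ccccc2)cc1F`, with -1.25 in a physicochemical assay for lipophilicity, using the shake flask method, at pH 7.4; on this read-out higher numbers stand for higher lipophilicity and lower numbers for lower lipophilicity
compound 2 `CC(C)(Oc1ccccc1)C(=O)Nc1ccc(OCC(=O)O)c(F)c1`, with "not determined" (no result reported) in this assay
compound 3 `Cc1ccccc1OCC(=O)Nc1ccc(OCC(=O)O)c(F)c1`, with "not determined" (no result reported) in this assay

Of the three measured compounds, only compound 1 comes with a number: in this assay compound 1 gives -1.25. In this assay compound 2 gives "not determined" (no result reported), and compound 3 gives "not determined" (no result reported), so compound 3 stands nowhere on the numbers shown; it shares this position with one further compound. For the measured compounds named here, no step between measured compounds is available, and nothing can be said about how compound 3 compares with compound 1 beyond the fact that only compound 1 has a value.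

The piece follows the step from compound 3 to compound 4 `Cc1cccc(OCC(=O)Nc2ccc(OCC(=O)O)c(F)c2)c1`. The change is 3-methylphenyl in place of 2-methylphenyl on an oxygen on a saturated carbon. The two compounds have the same atoms, joined differently, and the difference, cut one bond further out, reads 2-methylphenoxy to 3-methylphenoxy. Going by the values given here, with no measured step of this kind to draw on, the expectation in this assay is a step of no size beyond the scatter, in neither direction.

For compound 4, the estimate must rest on compound 1, whose value is -1.25, since compound 3 has none. Compound 4 is expected to give -0.85 in this assay, with a range from -1.6 to -0.1.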

Compound 4, distribution coefficient: -0.99
For compound 4 the middle estimate is 0.14 log units above the measured one, within the range that was stated.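

For the compounds shown here, compound 4 gives the series its first number for an aromatic ring that carries a methyl, and with it the first readable step in this assay, a number 0.26 log units higher from compound 1 to compound 4 (within the scatter), so methyl in place of hydrogen on an aromatic carbon, here in the form of 3-methylphenyl, stays within the usual scatter of the unsubstituted compound. The exchange of 2-methylphenyl for 3-methylphenyl itself, and every other step that involves compound 2 or compound 3, cannot be read: neither of these compounds has a number in this assay. No measurement shown offers an explanation for the result.

On these data alone, it remains open whether 2-methylphenyl would read the same as 3-methylphenyl on an oxygen on a saturated carbon, and what the added substitution on the saturated carbon in compound 2 would do to the number. Going by these compounds alone, also open is how the read-out would respond if a methoxy group, a chlorine atom or an amine stood in place of the methyl of 3-methylphenyl, since only one substituted ring has a number so far.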